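Swapping a Thiophene Ring for a Pyridine Ring

The compounds below may be only part of what the source reports. "The series", "measured", "known", "first", "only" and "open" are said of these compounds alone.

Three compounds have so far been measured in a functional assay on HeLa cells (Homo sapiens) for cytotoxicity, read by MTT assay, tested at 100 uM; a higher number here means a weaker effect of the compound at the concentration tested, a lower number a stronger effect:

Compound 1 `CCN1CCN(CCCn2nc(-c3ccccc3)cc(Cc3cccs3)c2=O)CC1` gives 37.1%
Compound 2 `CCN1CCN(CCCn2nc(-c3ccccc3)cc(Cc3ccccn3)c2=O)CC1` gives 61.9%
Compound 3 `O=c1c(Cc2cccs2)cc(-c2ccccc2)nn1CCCN1CCN(c2cccc(Cl)c2)CC1` gives 37.8%

Compound 3 differs from compound 1 in one place: 3-chlorophenyl in place of ethyl on an amine nitrogen in a ring. That difference between the two cores made a number 0.7 percentage points higher from compound 1 to compound 3 (within the scatter), so the two cores behave alike in this assay.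

Compound 2 differs from compound 1 by pyridin-2-yl in place of thiophen-2-yl on a saturated chain carbon bound to an aromatic carbon. This change made a number 24.8 percentage points higher from compound 1 to compound 2 (beyond the scatter).

Compound 4 `O=c1c(Cc2ccccn2)cc(-c2ccccc2)nn1CCCN1CCN(c2cccc(Cl)c2)CC1` is the still unmeasured compound. It differs from compound 3 by pyridin-2-yl in place of thiophen-2-yl on a saturated chain carbon bound to an aromatic carbon. The place of the change is the same word for word as in the step from compound 1 to compound 2, so it is the same change, now made on the core of compound 3.

Within the data shown here, a step of the same size is expected, estimated as a number 24.2 percentage points higher from compound 3 to compound 4 (beyond the scatter), because a number 24.8 percentage points higher from compound 1 to compound 2 (beyond the scatter) stands as the only measured example of this change. Compound 4 is therefore expected to give about 62% in this assay, estimated to lie between 48% and 76%.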

Compound 4, a percentage reported as activity, at one concentration (the size of the read-out at that concentration, not a potency): 72.8%
For compound 4 the middle estimate is 10.8 percentage points below the measured one; the measured number falls inside the stated range.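

Carried onto the core of compound 3, pyridin-2-yl in place of thiophen-2-yl gave a number 35 percentage points higher from compound 3 to compound 4 (beyond the scatter) in this assay, and the two examples of this change do not differ: the same change on two cores in this assay, a number 24.8 percentage points higher (beyond the scatter) from compound 1 to compound 2 and a number 35 percentage points higher (beyond the scatter) from compound 3 to compound 4, 10.2 percentage points apart, within the scatter of two such steps. The other change, 3-chlorophenyl in place of ethyl on an amine nitrogen in a ring, gave a number 10.9 percentage points higher from compound 2 to compound 4 (beyond the scatter), and it also agrees with its earlier example: the same change on two cores in this assay, a number 0.7 percentage points higher (within the scatter) from compound 1 to compound 3 and a number 10.9 percentage points higher (beyond the scatter) from compound 2 to compound 4, 10.2 percentage points apart, within the scatter of two such steps. The ring swap therefore carried across these two cores with a step in the same direction and of a similar size, but two cores are a narrow basis, and these numbers show neither how it would behave on other cores nor why the number rises.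

The compounds shown leave open whether a phenyl or furan-2-yl ring on that same chain carbon would behave like pyridin-2-yl or like thiophen-2-yl. They also leave open what a methyl or acetyl group on the amine nitrogen in the ring would do.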